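A few compounds are considered here, and "the series" means these few. Any claim that something is new, unique, unknown or untested is made for them only; others in the source may bear on it.

Measured so far:
Compound 1, `COc1ccc(CNc2nc3cc(N)cc(N)c3nc2-c2ccccc2)cc1OC`: in a functional assay on SK-OV-3 cells (Homo sapiens) for inhibition, read by sulforhodamine B assay, with a stated time of 48 h (on this read-out higher numbers stand for weaker inhibition of growth and lower numbers for stronger inhibition of growth), compound 1 gives 46800 nM.
Compound 2, `Nc1cc(N)c2nc(-c3ccccc3)c(NCc3ccc(F)cc3)nc2c1`: in this assay compound 2 gives 26300 nM.

Among the compounds with values here, compound 2 carries the lower of the two numbers, but the only measured step, a 1.8-fold lower number from compound 1 to compound 2 (0.25 log units; within the scatter), lies within the scatter, so the two compounds cannot be told apart on these data.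

Compound 3, `COc1ccc(CNc2nc3cc(N)cc(N)c3nc2-c2ccccc2)cc1`, differs from compound 2 in one place: methoxy in place of fluoro on an aromatic carbon. Within the data shown here, the one step that bears on this change is the swap of the benzyl substitution pattern, a 1.8-fold lower number from compound 1 to compound 2 (0.25 log units; within the scatter), which already exchanged a methoxy-bearing ring for the fluoro-bearing one without moving the number beyond the scatter. Since compound 3 now carries a single methoxy where compound 2 has fluoro, and compound 1 with its two methoxy groups gave 46800 nM, a number between those of compound 1 and compound 2 seems the most reasonable expectation, and no step beyond the scatter is expected.

The step of a 1.3-fold higher number from compound 2 to compound 3 (0.12 log units; within the scatter) is therefore expected to be small. Compound 3 is estimated at 35000 nM, with a likely range from 15000 nM to 80000 nM.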

Compound 3, concentration for total growth inhibition: 57500 nM
Beside the measured number, compound 3's estimate is 1.6-fold (0.22 log units) below it; low and high end bracket the measured number.
By their numbers in this assay, from the lowest: compounds 2, 1 and 3 (each within the scatter of the next, the first and the last beyond it).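

In this assay, within the data shown here, the exchange of 4-fluorobenzyl for 4-methoxybenzyl gives a 2.2-fold higher number from compound 2 to compound 3 (0.34 log units; beyond the scatter) and is the first step to clear the usual scatter, though only modestly, so the group para to a large group on this ring can register in the number. Among these compounds, putting hydrogen in place of a methoxy gives a 1.2-fold higher number from compound 1 to compound 3 (0.09 log units; within the scatter) and stays within the scatter, so the one methoxy of compound 3 and the two of compound 1 cannot be told apart here. Nothing measured alongside these numbers offers an explanation for the step from fluoro to methoxy.

Going by these compounds, with only fluoro and methoxy compared at this place, it remains open how chlorine, a hydroxyl group or an unsubstituted benzyl ring would read, and therefore whether the fluoro or the methoxy is the unusual one. On these data alone, it is also open whether a longer chain in place of the benzyl group, or a change on the shared core, would move the number further than these small steps do.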